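Sulfonamide Swap on a Trifluoromethylquinoline Thiourea Series

The source may hold more compounds than are shown below. What is called first, only, known or untested is meant among the compounds shown, and "the series" means these compounds.

The account begins with two measured compounds. Compound 1 `Nc1ccc(S(=O)(=O)Nc2ccnc3cc(C(F)(F)F)ccc23)cc1` gives 29200 nM in a functional assay on AS49-RAW cells (Homo sapiens) for antiproliferative activity, read by sulforhodamine B assay, with a stated time of 48 h; a lower number here means a stronger inhibitor, a higher number a weaker inhibitor. Compound 2 `Cc1noc(NS(=O)(=O)c2ccc(N/C(S)=N\c3ccnc4cc(C(F)(F)F)ccc34)cc2)c1C` gives 34000 nM in this assay. Within the data shown here, these two numbers sit within the usual scatter of each other, so compound 2 cannot be separated from compound 1; both are weak inhibitors on the scale of this assay, and no step between them is on record beyond what the two values themselves show.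

Compound 3 `COc1cc(NS(=O)(=O)c2ccc(N/C(S)=N\c3ccnc4cc(C(F)(F)F)ccc34)cc2)nc(OC)n1` has not yet been measured. It differs from compound 2 in a single place: 2,6-dimethoxypyrimidin-4-yl in place of 3,4-dimethyl-1,2-oxazol-5-yl on a sulfonamide nitrogen. The group that leaves and the group that enters are both aromatic rings with two hetero atoms, attached through the same sulfonamide nitrogen, whose other neighbour is the sulfonyl sulfur.

Among the measured compounds shown here, with no measured step of this kind available, a change of no more than the scatter is expected in this assay, in either direction, and the step of a 1.1-fold lower number from compound 2 to compound 3 (0.05 log units; within the scatter) is estimated accordingly. Compound 3 is therefore expected to give about 30000 nM in this assay, with a range from 10000 nM to 90000 nM.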

Compound 3, half-maximal inhibitory concentration: 64500 nM
Compound 3: the middle estimate sits 2.2-fold (0.33 log units) below what was measured; measured number inside the range.
By their numbers in this assay, from the lowest: compounds 1, 2 and 3 (each within the scatter of the next, the first and the last beyond it).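

In this assay the exchange of 3,4-dimethyl-1,2-oxazol-5-yl for 2,6-dimethoxypyrimidin-4-yl on the sulfonamide nitrogen reads as a 1.9-fold higher number from compound 2 to compound 3 (0.28 log units; within the scatter) and stays within the scatter, so the two numbers cannot be separated. Among these compounds, this is the first single-place reading at this position, and it shows that a five-membered aromatic ring can give way to a larger six-membered aromatic ring with more hydrogen-bond acceptors without a step that can be told from the scatter, while the numbers remain weak on the scale of this assay. No measurement on hand bears on why the step is this size.

As far as these compounds go, only these two groups are compared on this sulfonamide nitrogen, so it remains open whether a plain hydrogen, a methyl group or an unsubstituted phenyl ring there would also stay within the scatter. Among the compounds shown here, also open is what the thiourea link contributes, as compound 1 and compound 2 differ in more than one place and no single-place step reads it, so a urea or an amide in its stead would be needed to show this.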